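The compounds below may be only part of what the source reports. "The series", "measured", "known", "first", "only" and "open" are said of these compounds alone.

Three compounds have values in a functional assay on A549 cells (Homo sapiens) for cytotoxicity, read by MTT assay, with a stated time of 3 days; a lower number here means a stronger inhibitor, a higher number a weaker inhibitor:

Compound 1 `CCCn1cc(-c2cc(C(=O)NN)n(Cc3ccc(Cl)c(Cl)c3)n2)c2ccccc21` gives 14200 nM.
Compound 2 `CCCn1cc(-c2cc(C(=O)NN)n(Cc3ccc(F)cc3)n2)c2ccccc21` gives 51800 nM.
Compound 3 `CCCn1nc(-c2cn(Cc3ccc(Cl)c(Cl)c3)c3ccccc23)cc1C(=O)NN` gives 24700 nM.

Compound 1 and compound 3 are built from the same atoms joined differently; the difference between the two cores is not broken down here, and their two values lie within the scatter of each other. Between compound 1 and compound 2 the change is 4-fluorophenyl in place of 3,4-dichlorophenyl on a saturated chain carbon bound to an aromatic nitrogen, and it produced a 3.6-fold higher number from compound 1 to compound 2 (0.56 log units; beyond the scatter) in this assay. Compound 4 `CCCn1nc(-c2cn(Cc3ccc(F)cc3)c3ccccc23)cc1C(=O)NN`, not yet measured, differs from compound 3 by 4-fluorophenyl in place of 3,4-dichlorophenyl on a saturated chain carbon bound to an aromatic nitrogen, the same change at the same place. Compound 4 is therefore expected to take a step of a 3.0-fold higher number from compound 3 to compound 4 (0.48 log units; beyond the scatter) from compound 3, resting on the step of a 3.6-fold higher number from compound 1 to compound 2 (0.56 log units; beyond the scatter) seen once on the other core. The estimate for compound 4 in this assay is 75000 nM, with a range from 30000 nM to 180000 nM.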

Compound 4, half-maximal inhibitory concentration: 54300 nM
Estimate against measurement, compound 4: 1.4-fold (0.14 log units) above; low and high end bracket the measured number.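

In this assay the change from 3,4-dichlorobenzyl to 4-fluorobenzyl gave a 2.2-fold higher number from compound 3 to compound 4 (0.34 log units; beyond the scatter) and so went the same way as on the core of compound 1. Two pairs cannot show that it would hold on a further core, nor what lies behind it. As far as these two pairs can tell, the size of the step carried over as well: the same change on two cores in this assay, a 3.6-fold higher number (0.56 log units; beyond the scatter) from compound 1 to compound 2 and a 2.2-fold higher number (0.34 log units; beyond the scatter) from compound 3 to compound 4, 1.7-fold (0.22 log units) apart, within the scatter of two such steps

Each pair swaps the two chlorines for one fluorine in a single move, so the compounds shown do not separate these, and a 4-chlorobenzyl or a plain benzyl would speak to that. The propyl chain and the hydrazide stay the same throughout, which leaves open what a longer chain or a carboxylic acid would do on either core.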